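The source may hold more compounds than are shown below. What is called first, only, known or untested is meant among the compounds shown, and "the series" means these compounds.

Measured compounds:
- compound 1, `COCCNC(=O)[C@H]1CC[C@@H](Nc2ncc3c(Br)nn(-c4ccc5ncccc5c4)c3n2)CC1`: 211 nM
- compound 2, `CNC(=O)[C@]1(C)CC[C@@H](Nc2ncc3c(Br)nn(-c4ccc(-c5nnc(C)o5)cc4)c3n2)C1`: 16 nM

In an assay on isolated protein for inhibition of eIF-2-alpha kinase GCN2 (Homo sapiens) (on this read-out lower numbers stand for stronger inhibition and higher numbers for weaker inhibition), compound 2 gives the lower of the two numbers, and its distance to compound 1 lies beyond the scatter. Compound 3, `CNC(=O)[C@]1(C)CC[C@@H](Nc2ncc3c(Br)nn(-c4ccc(-c5ncc(C)s5)cc4)c3n2)C1`, is not yet measured. It keeps the shared core of compound 2 and differs in one place: 5-methyl-1,3-thiazol-2-yl in place of 5-methyl-1,3,4-oxadiazol-2-yl on an aromatic carbon. Going by the values given here, there is no measured pair that shows this particular exchange, so its effect is unknown. Since the two groups have the same count of heavy atoms and one five-membered aromatic ring each, compound 3 is expected to stay close to compound 2 in this assay, with a step of a 1.3-fold higher number from compound 2 to compound 3 (0.10 log units; within the scatter) that does not go beyond the scatter in either direction. Compound 3 is therefore estimated at 20 nM, with a range from 6 nM to 60 nM.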

Compound 3, half-maximal inhibitory concentration: 76 nM
The estimate for compound 3 lay 3.8-fold (0.58 log units) below the measured number, outside the stated range (above it).
By their numbers in this assay, from the lowest: compound 2; then compound 3; then compound 1.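

In this assay, putting 5-methyl-1,3-thiazol-2-yl in place of 5-methyl-1,3,4-oxadiazol-2-yl gives a 4.8-fold higher number from compound 2 to compound 3 (0.68 log units; beyond the scatter), so this place on the aromatic carbon, para to a large group, does not treat the two groups alike. The two groups have the same count of heavy atoms and one five-membered aromatic ring each, which shows that these shared features alone do not hold the number steady here. They differ in their hetero atoms and hydrogen-bond acceptors, but nothing available here connects either difference to the step. Going by these compounds alone, with only this one exchange at this place, it remains open which of the changed ring atoms carries the step. Also open, going by these compounds, is where a 5-methyl-1,3-oxazol-2-yl group or a primary carboxamide would fall on the same core.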